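Fluoro to Methoxy: Expecting Tolerance to Hold

The source may report more compounds than this note shows. Statements on the series, on what has been measured and on what is new or still open speak of the compounds shown alone.

Measured compounds:
- compound 1, `COc1nc(-c2ccc(Cl)cc2)ccc1[C@@H](c1ccccc1)[C@@](O)(CCN(C)C)c1cccc2ccccc12`: > 50 ug/mL
- compound 2, `COc1nc(-c2ccc(F)cc2)ccc1[C@@H](c1ccccc1)[C@@](O)(CCN(C)C)c1cccc2ccccc12`: > 50 ug/mL

Compound 2 stands at a limit in a toxicity assay on Vero cells (Chlorocebus sabaeus) for cytotoxicity; a lower number here means that less compound is tolerated, a higher number that more compound is tolerated. Compound 2 gives > 50 ug/mL, which is a limit of the assay and not a number. Compound 1 also sits at a limit in this assay, giving > 50 ug/mL. For the measured compounds named here, both values rest on the same boundary (the limit of > 50 ug/mL in this assay, at which 2 of the 2 values shown sit), so the one measured step, a step that the two limits leave unreadable from compound 1 to compound 2, cannot be read as a size in either direction.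

Compound 3, `COc1ccc(-c2ccc([C@@H](c3ccccc3)[C@@](O)(CCN(C)C)c3cccc4ccccc34)c(OC)n2)cc1`, is the next compound and has not yet been measured. It differs from compound 2 in one place: methoxy in place of fluoro on an aromatic carbon.

Going by the values given here, no measured step bears on this change in a readable way, since the only step available lies between two limits. The two measured compounds simply show that the shared core is tolerated up to the limit of this assay with either halogen. Compound 3 is therefore expected to stay at or near that limit, with no step beyond the scatter foreseen. The step expected is a step that the limit leaves unreadable from compound 2 to compound 3. Compound 3 is estimated at 60 ug/mL, within a range from 30 ug/mL to 120 ug/mL.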

Compound 3, half-maximal cytotoxic concentration: > 50 ug/mL
Compound 3 was reported as a limit; the forecaster's own chance of this, stated with the estimate: 70%; the middle value lies beyond the limit too.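

In this assay compound 3 gives > 50 ug/mL, which is a limit of the assay and not a number. The steps among compound 1, compound 2 and compound 3 therefore cannot be read in size or direction: the limit of > 50 ug/mL in this assay, at which 3 of the 3 values shown sit.

What stays open is the concentration at which each of these compounds reaches its half-maximal cytotoxic effect, and whether chloro, fluoro and methoxy differ at all.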